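A second chloro on the aryl ring of compound 2

The source may report more compounds than this note shows. Statements on the series, on what has been measured and on what is new or still open speak of the compounds shown alone.

Of the compounds shown here, two have so far been measured in a functional assay on RPMI8266 cells (Homo sapiens) for inhibition, read by sulforhodamine B assay, with a stated time of 48 h; a higher number here means a weaker inhibitor of growth, a lower number a stronger inhibitor of growth. Compound 1 `N#C/C(=C\N1CCN(C(=O)c2ccco2)C1=S)C(N)=O` gives 12400 nM, while compound 2 `O=CN1CCN(c2ccc(Cl)cc2)C1=S` gives 3400 nM, the lower of the two numbers and beyond the scatter from compound 1. Compound 3 `O=CN1CCN(c2ccc(Cl)c(Cl)c2)C1=S` differs from compound 2 by chloro in place of hydrogen on an aromatic carbon. Among the measured compounds shown here, with no step of this kind measured, the expected change in this assay is small: the step of a 1.4-fold lower number from compound 2 to compound 3 (0.13 log units; within the scatter) is estimated to stay within or near the scatter, leaning toward a slightly lower number. Compound 3 is thus expected near 2500 nM, between 900 nM and 8000 nM.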

Compound 3, concentration for 50% growth inhibition: 2800 nM
Beside the measured number, compound 3's estimate is 1.1-fold (0.05 log units) below it, and the stated range covers the measured number.
By their numbers in this assay, from the lowest: compounds 3 and 2 (each within the scatter of the next); then compound 1.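

In this assay, chloro in place of hydrogen on this aromatic carbon, ortho to a chloro group, gives a step within the scatter (a 1.2-fold lower number from compound 2 to compound 3 (0.08 log units; within the scatter)). Among the compounds shown here, this position therefore takes a second chloro with no change that can be told from the scatter, a point the earlier compounds could not show. No measurement offered here bears on this result. The compounds shown leave open whether an amine or a carboxylic acid on this carbon would give a number beyond the scatter from compound 2. They also leave open what the chloro already present in compound 2 contributes.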